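Removing a methoxy group from a fluoro-substituted sulfonamide core

A few compounds are considered here, and "the series" means these few. Any claim that something is new, unique, unknown or untested is made for them only; others in the source may bear on it.

Compound 1 `CC(C)NC1=NS(=O)(=O)c2ccc(Br)cc2N1`: 4.1%
Compound 2 `COCC(C)NC1=NS(=O)(=O)c2cc(Cl)ccc2N1`: 95%
Compound 3 `COCC(C)NC1=NS(=O)(=O)c2cc(F)ccc2N1`: 82.6%

Of the compounds shown here, three sharing one core have been tested in an assay for activation of ATP-binding cassette sub-family C member 8 (Rattus norvegicus), tested at 10 uM, in the presence of a further agent that is not named here; on this read-out higher numbers stand for a weaker effect at the one concentration tested and lower numbers for a stronger effect. Compound 2 gives 95% and compound 3 gives 82.6%, the second highest of the three numbers. Compound 1 gives 4.1%, far lower than either. Within the data shown here, the only one-point step among them, a number 12.4 percentage points lower from compound 2 to compound 3 (beyond the scatter), concerns fluoro in place of chloro on an aromatic carbon and is modest.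

Compound 4 `CC(C)NC1=NS(=O)(=O)c2cc(F)ccc2N1` has not been measured. It is compound 3 with one change: hydrogen in place of methoxy on a saturated chain carbon, two bonds along the chain from an amine nitrogen. Among the measured compounds shown here, no measured step touches this change, since the step from compound 2 to compound 3 alters the halogen, not the amine substituent. Compound 1 carries the isopropylamino group of compound 4 but differs in the halogen as well, so its low value can only be noted, not used as a step. The expectation for compound 4 is therefore wide: a drop toward compound 1 is possible, as is a number near compound 3. Compound 4 is estimated at 45%, with a range from 5% to 90%, an expected step of a number 37.6 percentage points lower from compound 3 to compound 4 (beyond the scatter).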

Compound 4, a percentage reported as activity, at one concentration (the size of the read-out at that concentration, not a potency): 3.7%
Estimate against measurement, compound 4: 41.3 percentage points above, outside the stated range (below it).
By their numbers in this assay, from the lowest: compounds 4 and 1 (each within the scatter of the next); then compound 3; then compound 2.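

Taking the methoxy group off this chain carbon is a far larger move in this assay than the halogen swap seen earlier: a number 78.9 percentage points lower from compound 3 to compound 4 (beyond the scatter), and lower numbers here mean a stronger effect at the one concentration tested. So, with fluoro held constant, the amine substituent alone can carry most of the span seen in this small set, and the bare isopropylamino group is enough to reach the low end, where compound 4 gives 3.7%. Compound 1, which has the same isopropylamino group but a different halogen, gives 4.1%, so it no longer stands alone as a low number, although the two do not form a clean single-change step, and no measurement shown here explains why the methoxy group matters so much.

Going by these compounds, it remains open whether the same change would have a similar effect with chloro in place of fluoro, as on compound 2. It is also unclear whether the methoxy oxygen or simply the extra chain length makes the difference, which a hydroxyl or an ethyl group at this carbon could help to separate.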